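The source may hold more compounds than are shown below. What is called first, only, known or untested is meant among the compounds shown, and "the series" means these compounds.

Measured compounds:
- compound 1, `C[C@H](Nc1ncnc2[nH]cnc12)c1cc2ccc(F)cn2c(=O)c1-c1ccccc1`: 98%
- compound 2, `Cc1nc(N)c(C#N)c(N[C@@H](C)c2cc3ccc(F)cn3c(=O)c2-c2ccccc2)n1`: "not determined" (no result reported)

In an ADME assay on microsomes from liver (Homo sapiens), read by LC-MS, using NADPH, with a stated time of 30 min, tested at 1 uM (on this read-out higher numbers stand for a more stable compound and lower numbers for a less stable compound), compound 1 gives 98%. Compound 2 has no single number in this assay, so its standing cannot be placed. Compound 3, `Cc1nc(N)nc(N[C@@H](C)c2cc3ccc(F)cn3c(=O)c2-c2ccccc2)c1C#N`, differs from compound 2 by 2-amino-5-cyano-6-methylpyrimidin-4-yl in place of 6-amino-5-cyano-2-methylpyrimidin-4-yl on an amine nitrogen. For the measured compounds named here, with no measured step to lean on, the change is expected to stay within the usual scatter of this assay, with no clear direction. Compound 3 is therefore estimated to remain at 85%, within a range from 60% to 100%.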

Compound 3, percent of the compound remaining: 83%
Compound 3: the middle estimate sits 2 percentage points above what was measured, within the range that was stated.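

In this assay, the group on the amine nitrogen proves able to shift the read-out: there is a number 15 percentage points lower from compound 1 to compound 3 (beyond the scatter). The pyrimidine group of compound 3 therefore leaves a measurable mark, though compound 3 still keeps most of its material. No measurement shown here gives a reason for this step.

Going by these compounds, the swap between compound 2 and compound 3 cannot be read, as compound 2 has no result, so the effect of rearranging the amino and methyl groups stays open. Also open, on these data alone, is how a carboxylic acid in place of the nitrile would score.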